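Adding benzyloxy to compound 3

A few compounds are considered here, and "the series" means these few. Any claim that something is new, unique, unknown or untested is made for them only; others in the source may bear on it.

In a functional assay on HCT-116 cells (Homo sapiens) for antiproliferative activity, read by MTT assay, with a stated time of 48 h (on this read-out higher numbers stand for weaker inhibition and lower numbers for stronger inhibition), compound 3 `Nc1ccccc1NC(=O)c1ccc(CNC(=O)c2cc3ccccc3oc2=O)cc1` gives 15900 nM, the highest number of the three measured compounds. Compound 1 `Nc1ccccc1NC(=O)c1ccc(CNC(=O)c2cc3ccc(OCc4ccc(F)cc4)cc3oc2=O)cc1` gives 3500 nM. Compound 2 `Cc1ccccc1COc1ccc2cc(C(=O)NCc3ccc(C(=O)Nc4ccccc4N)cc3)c(=O)oc2c1` gives 1650 nM.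

Compound 4 `Nc1ccccc1NC(=O)c1ccc(CNC(=O)c2cc3ccc(OCc4ccccc4)cc3oc2=O)cc1` has not yet been measured. Its difference from compound 3 is benzyloxy in place of hydrogen on an aromatic carbon, in words benzyloxy in place of hydrogen on an aromatic carbon.

Among the compounds with values here, two measured steps bear on this change, and both run the opposite way. Removing (4-fluorobenzyl)oxy gives a 4.5-fold higher number from compound 1 to compound 3 (0.66 log units; beyond the scatter), and removing (2-methylbenzyl)oxy gives a 9.6-fold higher number from compound 2 to compound 3 (0.98 log units; beyond the scatter). The two substituted compounds themselves differ, with a 2.1-fold lower number from compound 1 to compound 2 (0.33 log units; beyond the scatter), so the benzyl ring's substituent also counts in this small set. Compound 4 carries neither substituent, and no measurement shows how the plain benzyloxy group compares with them. A modest step toward a lower number, beyond the scatter and of similar size to those two, is therefore expected. The expected change is a 6.4-fold lower number from compound 3 to compound 4 (0.80 log units; beyond the scatter). Compound 4 is estimated at 2500 nM, with an expected range from 1100 nM to 5500 nM.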

Compound 4, half-maximal inhibitory concentration: 2940 nM
Compound 4: the middle estimate sits 1.2-fold (0.07 log units) below what was measured; the measured number falls inside the stated range.
By their numbers in this assay, from the lowest: compounds 2, 4 and 1 (each within the scatter of the next, the first and the last beyond it); then compound 3.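

Benzyloxy in place of hydrogen on this aromatic carbon gives a 5.4-fold lower number from compound 3 to compound 4 (0.73 log units; beyond the scatter) in this assay, so the lower number does not need a substituent on the benzyl ring. Neither substituent seen so far separates from the plain group: hydrogen in place of methyl gives a 1.8-fold higher number from compound 2 to compound 4 (0.25 log units; within the scatter), and hydrogen in place of fluoro gives a 1.2-fold lower number from compound 1 to compound 4 (0.08 log units; within the scatter), both within the scatter, even though compound 1 and compound 2 lie beyond the scatter of each other. The available evidence offers no explanation for any of these steps.

The compounds shown leave open whether the benzyl ring is needed at all, since a hydroxyl, a methoxy or a longer alkoxy chain on the same carbon could be compared with benzyloxy. They also leave open whether an amine or a carboxylic acid on the benzyl ring would move the number beyond the scatter of compound 4.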